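Swapping chloro for methoxy on a hydrazone series

The source may hold more compounds than are shown below. What is called first, only, known or untested is meant among the compounds shown, and "the series" means these compounds.

Compound 1, `COc1cc(/C=N/NC(=O)CCCc2nc3ccccc3c(=O)[nH]2)cc(O)c1O`: 88000000 nM
Compound 2, `O=C(CCc1nc2ccccc2c(=O)[nH]1)N/N=C/c1ccc(Cl)cc1`: 381000000 nM
Compound 3, `O=C(CCCc1nc2ccccc2c(=O)[nH]1)N/N=C/c1ccc(Cl)cc1`: 353000000 nM

In a physicochemical assay, read by spectrophotometry, with a stated time of 30 min (on this read-out higher numbers stand for weaker inhibition and lower numbers for stronger inhibition), compound 2 gives the highest number of the three. Compound 3 lies within the scatter of compound 2, so the two cannot be told apart, while compound 1 lies beyond the scatter with a lower number, which here means stronger inhibition. Compound 4, `COc1ccc(/C=N/NC(=O)CCc2nc3ccccc3c(=O)[nH]2)cc1`, differs from compound 2 in one place: methoxy in place of chloro on an aromatic carbon. Among the compounds with values here, no measured pair of compounds shows this same change, so its effect is unknown from these numbers. The expected step of a 1.3-fold lower number from compound 2 to compound 4 (0.10 log units; within the scatter) is therefore small, leaning only faintly toward a lower number and staying within the scatter. Compound 4 is expected to give 300000000 nM, with a likely range from 120000000 nM to 750000000 nM.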

Compound 4, half-maximal inhibitory concentration: 214000000 nM
Estimate against measurement, compound 4: 1.4-fold (0.15 log units) above; low and high end bracket the measured number.
By their numbers in this assay, from the lowest: compound 1; then compounds 4, 3 and 2 (each within the scatter of the next).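

The swap from 4-chlorophenyl to 4-methoxyphenyl now has a direct reading in this assay as a 1.8-fold lower number from compound 2 to compound 4 (0.25 log units; within the scatter) and so the two groups cannot be told apart at this place on the aromatic ring. This holds even though methoxy brings a hydrogen-bond acceptor that chloro lacks. Nothing available offers an explanation for this result.

Still open, from the compounds shown here alone, is whether an amine or a carboxylic acid at this place would give a number beyond the scatter of compound 2. Also open, going by these compounds, is whether the same swap reads alike on the chain of compound 3.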